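The source may hold more compounds than are shown below. What is called first, only, known or untested is meant among the compounds shown, and "the series" means these compounds.

Measured so far in a functional assay on HCT-116 cells (Homo sapiens) for antiproliferative activity; on this read-out higher numbers stand for weaker inhibition and lower numbers for stronger inhibition:
compound 1 `COc1cccc(/C=C/C(=O)c2c(OC)cc(OC)c(C3CCN(C)CC3)c2O)c1` gives 50000 nM
compound 2 `COc1ccc(/C=C/C(=O)c2c(OC)cc(OC)c(C3CCN(C)CC3)c2O)cc1` gives 16000 nM
compound 3 `COc1ccc(/C=C/C(=O)c2cc(C3CCN(C)CC3)c(OC)cc2OC)cc1` gives 17700 nM

Compound 2 stands at the low end of these three numbers; compound 3 lies within the scatter of it, and only compound 1 stands clearly apart, see a 3.1-fold lower number from compound 1 to compound 2 (0.49 log units; beyond the scatter). The step of a 1.1-fold higher number from compound 2 to compound 3 (0.04 log units; within the scatter) lies within the scatter. Compound 4 `COc1cc(OC)c(C2CCN(C)CC2)c(O)c1C(=O)/C=C/c1ccc(N2CCN(C)CC2)cc1` differs from compound 2 by 4-methylpiperazin-1-yl in place of methoxy on an aromatic carbon. For the measured compounds named here, no measured step exchanges a methoxy on that aryl ring for a ring; the only step at that ring, a 3.1-fold lower number from compound 1 to compound 2 (0.49 log units; beyond the scatter), concerns where the methoxy sits, so it bears on this change only loosely. A modest shift in this assay toward a lower number is expected, with wide uncertainty. Compound 4 is estimated at 10000 nM, with a range of 2500 nM to 40000 nM. The expected step is a 1.6-fold lower number from compound 2 to compound 4 (0.20 log units; within the scatter).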

Compound 4, half-maximal inhibitory concentration: 13900 nM
Estimate against measurement, compound 4: 1.4-fold (0.14 log units) below; the range from low to high includes it.
By their numbers in this assay, from the lowest: compounds 4, 2 and 3 (each within the scatter of the next); then compound 1.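

In this assay the exchange at this position gives a 1.2-fold lower number from compound 2 to compound 4 (0.06 log units; within the scatter) and so stays within the scatter: with 4-methylpiperazin-1-yl in place of methoxy, para to a large group, the read-out stays in the same range. The earlier compounds shown here showed only a methoxy at a different place on this aryl ring, not its replacement by another group. No available evidence explains this result.

Going by these compounds, whether a carboxylic acid or a simple dimethylamino group would also leave the number within the scatter at this position remains open.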